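Three Methoxy Groups Replace a Nitrile on the Benzyl Ether

This account rests on a few compounds, and the source may have more. Where it says the series, first, only, none or still open, it means among the compounds named here.

Compound 2 `N#Cc1ccc(COc2ccc(-c3cc(CN4CCN(Cc5ccc(C(F)(F)F)cc5)CC4)no3)cc2)cc1` gives 1000 nM in a functional assay on Huh-7 cells (Homo sapiens) for antiproliferative activity, read by sulforhodamine B assay, with a stated time of 72 h; on this read-out lower numbers stand for stronger inhibition and higher numbers for weaker inhibition. Among the three compounds measured so far, the number of compound 2 is the second highest, yet all three numbers sit within the usual scatter of one another. Compound 1 `Cc1ccc(COc2ccc(-c3cc(CN4CCN(Cc5ccc(C(F)(F)F)cc5)CC4)no3)cc2)cc1` gives 1500 nM in this assay, and compound 3 `COc1ccccc1COc1ccc(-c2cc(CN3CCN(Cc4ccc(C(F)(F)F)cc4)CC3)no2)cc1` gives 900 nM. The three share one core and differ only in the aromatic ring that sits on the saturated chain carbon bound to an oxygen on the aromatic ring. Swapping that ring changed little: the step of a 1.7-fold lower number from compound 1 to compound 3 (0.22 log units; within the scatter) and the step of a 1.1-fold lower number from compound 2 to compound 3 (0.05 log units; within the scatter) both fall within the scatter, as does a 1.5-fold lower number from compound 1 to compound 2 (0.18 log units; within the scatter).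

Compound 4 `COc1cc(COc2ccc(-c3cc(CN4CCN(Cc5ccc(C(F)(F)F)cc5)CC4)no3)cc2)cc(OC)c1OC` is the next variation at the same place. The change from compound 2 is 3,4,5-trimethoxyphenyl in place of 4-cyanophenyl on a saturated chain carbon bound to an oxygen on an aromatic ring. Because a 1.7-fold lower number from compound 1 to compound 3 (0.22 log units; within the scatter) and a 1.1-fold lower number from compound 2 to compound 3 (0.05 log units; within the scatter) stayed within the scatter, no step beyond the scatter is expected in this assay for this swap either; the expected step is a 1.1-fold lower number from compound 2 to compound 4 (0.05 log units; within the scatter). Compound 4 is therefore estimated to give 900 nM in this assay, with a range from 400 nM to 2000 nM.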

Compound 4, half-maximal inhibitory concentration: 500 nM
Estimate against measurement, compound 4: 1.8-fold (0.26 log units) above; measured number inside the range.
By their numbers in this assay, from the lowest: compounds 4, 3, 2 and 1 (each within the scatter of the next, the first and the last beyond it).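

Within the data shown here, at the aromatic ring on the saturated chain carbon bound to an oxygen on an aromatic ring, no earlier swap moved the number in this assay beyond the scatter, but 3,4,5-trimethoxyphenyl in place of 4-methylphenyl gives a 3.0-fold lower number from compound 1 to compound 4 (0.48 log units; beyond the scatter) as the first step that does, though only a modest one. The other two steps, a 2.0-fold lower number from compound 2 to compound 4 (0.30 log units; within the scatter) and a 1.8-fold lower number from compound 3 to compound 4 (0.26 log units; within the scatter) both stay within the scatter, so compound 4 cannot be told apart from the 4-cyanophenyl or the 2-methoxyphenyl compound, and only its pair with compound 1 shows that this position can respond at all. No measurement at hand says what lies behind that one step beyond the scatter, so the result stands as a plain observation.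

Every group shown at this position is a substituted phenyl ring, so the effect of a basic amine such as morpholine or of a carboxylic acid there remains open. Also open, as far as these compounds go, is whether ethoxy groups in place of the methoxy groups of compound 4 would keep its number or shift it.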